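Working notes: replacing the aryl group of compound 3

The compounds below may be only part of what the source reports. "The series", "measured", "known", "first", "only" and "open" are said of these compounds alone.

In a functional assay on MDA-MB-231 cells (Homo sapiens) for antiproliferative activity, read by MTT assay, with a stated time of 72 h (a lower number here means a stronger inhibitor, a higher number a weaker inhibitor), compound 1 `O=C(CCc1cccc2c1B(O)OC2)Nc1ccccc1` gives 230 nM, compound 2 `O=C(CCc1cccc2c1B(O)OC2)Nc1cccc(I)c1` gives 5300 nM and compound 3 `O=C(CCc1cccc2c1B(O)OC2)Nc1cccc(-c2ccc(Cl)cc2)c1` gives 260 nM. Compound 3 stands level with compound 1, within the scatter, as a 1.1-fold higher number from compound 1 to compound 3 (0.05 log units; within the scatter) shows. It lies far from the iodo compound, with a 20-fold lower number from compound 2 to compound 3 (1.31 log units; beyond the scatter).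

The next compound is compound 4 `O=C(CCc1cccc2c1B(O)OC2)Nc1cccc(-c2cccc(C(F)(F)F)c2)c1`, with 3-(trifluoromethyl)phenyl in place of 4-chlorophenyl on an aromatic carbon.

Among the compounds with values here, no measured step exchanges one aryl group for another, so the evidence is indirect. Adding 4-chlorophenyl left the number unchanged within the scatter, with a 1.1-fold higher number from compound 1 to compound 3 (0.05 log units; within the scatter), whereas iodo gave a large rise, with a 23-fold higher number from compound 1 to compound 2 (1.36 log units; beyond the scatter). The first of these steps is the closer match, since compound 4 also carries an added aryl group, but the second argues for a wide range. The expected this assay step is therefore small, a 1.3-fold higher number from compound 3 to compound 4 (0.13 log units; within the scatter), with none expected beyond the scatter. Compound 4 is estimated at 350 nM, with a range of 110 nM to 1400 nM.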

Compound 4, half-maximal inhibitory concentration: 410 nM
Beside the measured number, compound 4's estimate is 1.2-fold (0.07 log units) below it, within the range that was stated.
By their numbers in this assay, from the lowest: compounds 1, 3 and 4 (each within the scatter of the next); then compound 2.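

Within this assay, the first direct exchange of one aryl group for another on this aromatic carbon, a 1.6-fold higher number from compound 3 to compound 4 (0.20 log units; within the scatter) leaves the number within the scatter, although the ring's substituent changes from chlorine to trifluoromethyl. A second aryl group also repeats the large separation from the iodo compound, with a 13-fold lower number from compound 2 to compound 4 (1.11 log units; beyond the scatter) and with a 1.8-fold higher number from compound 1 to compound 4 (0.25 log units; within the scatter) still within the scatter; among the four compounds, only compound 2 stands apart from the rest. Nothing available here accounts for that separation or for the tolerance of the two aryl groups.

From the compounds shown here alone, it remains open whether an amine or a carboxylic acid on the added aryl ring, or a longer chain in its place, would stay level with compound 1. Also open, going by these compounds, is whether another small group, such as methoxy, would give a rise like that of compound 2.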